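A few compounds are considered here, and "the series" means these few. Any claim that something is new, unique, unknown or untested is made for them only; others in the source may bear on it.

Measured so far in an assay on HEK293 cells for inhibition of Indoleamine 2,3-dioxygenase 1 (Homo sapiens), tested at 10 uM; a higher number here means more inhibition at the concentration tested (going by the name of the read-out), a lower number less inhibition:
compound 1 `CC(=O)N1CCc2cc(CNC(=O)c3cccs3)ccc21` gives 72%
compound 2 `CCC(=O)N1CCc2cc(CNC(=O)c3cccs3)ccc21` gives 89%
compound 3 `CC(C)C(=O)N1CCc2cc(CNC(=O)c3cccs3)ccc21` gives 100%

Within this set compound 2 stands second highest of the three. Compound 3 lies nearest to it, a number 11 percentage points higher from compound 2 to compound 3 (beyond the scatter), and compound 1 furthest, a number 17 percentage points higher from compound 1 to compound 2 (beyond the scatter). All three steps among the measured compounds concern the same part of the shared core: methyl in place of hydrogen on a saturated chain carbon bound to a carbonyl carbon, or isopropyl in place of methyl on a carbonyl carbon, giving a number 17 percentage points higher from compound 1 to compound 2 (beyond the scatter), a number 28 percentage points higher from compound 1 to compound 3 (beyond the scatter) and a number 11 percentage points higher from compound 2 to compound 3 (beyond the scatter), each beyond the scatter and each modest.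

Compound 4 `CCC(=O)N1CCc2cc(CNC(=O)c3cccc(Cl)c3)ccc21` differs from compound 2 at another place: 3-chlorophenyl in place of thiophen-2-yl on a carbonyl carbon. Going by the values given here, none of the measured steps touches the carbonyl carbon whose other neighbour is the amide-type nitrogen, so no measured step bears directly on this change, and the data offer no guide to it. The part of the molecule that did move the numbers is the same in compound 2 and compound 4. With nothing to push the expectation either way, the expected step in this assay is a number 4 percentage points lower from compound 2 to compound 4 (within the scatter), none beyond the scatter. Compound 4 is therefore estimated at 85%, with a range from 60% to 100%.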

Compound 4, a percentage reported as inhibition, at one concentration (the size of the read-out at that concentration, not a potency): 77%
Estimate against measurement, compound 4: 8 percentage points above, and the stated range covers the measured number.
By their numbers in this assay, from the lowest: compounds 1 and 4 (each within the scatter of the next); then compound 2; then compound 3.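

In this assay, the carbonyl carbon whose other neighbour is an amide-type nitrogen proves to be a place where the read-out responds: 3-chlorophenyl in place of thiophen-2-yl gives a number 12 percentage points lower from compound 2 to compound 4 (beyond the scatter). Going by these compounds alone, the earlier compounds varied only the other carbonyl carbon, so this is the first sign that the thiophen-2-yl end also counts, and that this group is preferred to 3-chlorophenyl when the rest of the molecule is that of compound 2, although the step is modest and compound 4 still gives 77%. Nothing at hand accounts for this step, and the swap changes the ring and brings in chlorine at once, so the two contributions cannot be told apart.

A plain phenyl at this place would separate the effect of the ring from that of the chlorine, while a 4-chlorophenyl would show whether the site of the chlorine on the ring matters. Going by these compounds, it also remains open whether an isopropyl on the other carbonyl carbon, the group of compound 3, would raise the number when paired with 3-chlorophenyl as it does when paired with thiophen-2-yl.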